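The source may report more compounds than this note shows. Statements on the series, on what has been measured and on what is new or still open speak of the compounds shown alone.

In a functional assay on K562 cells (Homo sapiens) for inhibition, read by trypan blue exclusion, with a stated time of 72 h (on this read-out higher numbers stand for weaker inhibition and lower numbers for stronger inhibition), compound 2 `Cn1c(=O)c(S(=O)(=O)c2ccc(O)cc2)cc2cnc(Nc3ccc4[nH]ccc4c3)nc21` gives 100 nM, the lower of the two numbers measured, while compound 1 `Cn1c(=O)c(C(=O)Nc2ccc(F)cc2F)cc2cnc(Nc3ccc4[nH]ccc4c3)nc21` gives 5000 nM. Compound 3 `Cn1c(=O)c(S(=O)(=O)Nc2ccc(F)cc2F)cc2cnc(Nc3ccc4[nH]ccc4c3)nc21` carries (2,4-difluorophenyl)amino in place of 4-hydroxyphenyl on a sulfonyl sulfur. Within the data shown here, the one measured step bearing on this is the large 50-fold lower number from compound 1 to compound 2 (1.70 log units; beyond the scatter), which put (4-hydroxyphenyl)sulfonyl in place of (2,4-difluorophenyl)carbamoyl. Compound 3 keeps the sulfonyl but regains the 2,4-difluorophenyl group, so part of that step is expected to be lost in this assay. The expected change is an 8.0-fold higher number from compound 2 to compound 3 (0.90 log units; beyond the scatter), towards a higher number. For compound 3 the estimated value is 800 nM, with an expected range of 150 nM to 4000 nM.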

Compound 3, half-maximal inhibitory concentration: 5000 nM
For compound 3 the middle estimate is 6.3-fold (0.80 log units) below the measured one; measured number outside the range, above it.
By their numbers in this assay, from the lowest: compound 2; then compounds 1 and 3 (each within the scatter of the next).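

In this assay the change on the sulfonyl sulfur gives a 50-fold higher number from compound 2 to compound 3 (1.70 log units; beyond the scatter) so keeping the sulfonyl does not by itself keep the lower number. With the 2,4-difluorophenyl group present in both, compound 1 gives 5000 nM and compound 3 gives 5000 nM with carbamoyl and sulfonyl printing the same value. Nothing available explains this result. The compounds shown leave open whether the lower number of compound 2 depends on the hydroxyl or on the absence of the amino link. A plain phenyl or a (4-hydroxyphenyl)amino group on the sulfonyl sulfur would separate the two.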